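The source may hold more compounds than are shown below. What is called first, only, known or untested is meant among the compounds shown, and "the series" means these compounds.

Series on one shared core, varied at the carbonyl carbon attached to the ring nitrogen. Compound 1 `CC(=O)N1c2ccccc2CCC1C(=O)Nc1cc(C(F)(F)F)cc(C(F)(F)F)c1` carries methyl there; compound 2 `O=C(Nc1cc(C(F)(F)F)cc(C(F)(F)F)c1)C1CCc2ccccc2N1C(=O)c1ccc(Cl)cc1` carries 4-chlorophenyl. In a functional assay on ACHN cells (Homo sapiens) for cytotoxicity, read by sulforhodamine B assay, with a stated time of 72 h (on this read-out higher numbers stand for weaker inhibition of growth and lower numbers for stronger inhibition of growth), compound 1 gives only a limit, > 70000 nM; this is the limit of > 70000 nM in this assay, at which 1 of the 2 values shown sits. In this assay, among the measured compounds shown here, compound 2 gives 2570 nM, the only full number so far. For the measured compounds named here, the single measured step, an at least 27-fold lower number from compound 1 to compound 2 (1.43 log units; beyond the scatter), is therefore the sole guide. Compound 3 `CCCCCCCCC(=O)N1c2ccccc2CCC1C(=O)Nc1cc(C(F)(F)F)cc(C(F)(F)F)c1` takes the change (octyl in place of 4-chlorophenyl on a carbonyl carbon). The measured step bears on it only in that it shows the group on this carbonyl carbon matters strongly, but it compares methyl with an aryl group, not with a chain, so the direction for octyl is open and the uncertainty wide. The expectation for compound 3 is a 5.8-fold higher number from compound 2 to compound 3 (0.77 log units; beyond the scatter), a weakening that is expected to stop short of a limit. Compound 3 is estimated at 15000 nM, with a range from 3000 nM to 70000 nM.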

Compound 3, concentration for 50% growth inhibition: 4520 nM
Beside the measured number, compound 3's estimate is 3.3-fold (0.52 log units) above it; the range from low to high includes it.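

In this assay, octyl and 4-chlorophenyl on this carbonyl carbon cannot be told apart, with a 1.8-fold higher number from compound 2 to compound 3 (0.25 log units; within the scatter), so an aromatic ring in this place is not needed to reach this level of growth inhibition. The large change from methyl is also seen with a chain that has no ring, with an at least 15-fold lower number from compound 1 to compound 3 (1.18 log units; beyond the scatter). Compound 1 gives a limit, not a number, so that step has no exact size: the limit of > 70000 nM in this assay, at which 1 of the 3 values shown sits.

The compounds shown leave open how the response runs with chain length, from a shorter chain such as butyl to a longer one such as dodecyl. They also leave open whether plain phenyl matches 4-chlorophenyl, and whether a chain ending in an amine or a carboxylic acid matches octyl.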